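Fluorophenyl exchange on the core of compound 1

This account rests on a few compounds, and the source may have more. Where it says the series, first, only, none or still open, it means among the compounds named here.

Compound 1 `N#Cc1cc(-c2nc(C(c3ccc(F)cc3)c3ccc(F)cc3)sc2CC(=O)O)ccc1F` gives 80% in an in vitro functional assay on HEK285-7 cells for antagonist activity at prostaglandin D2 receptor 2 (Homo sapiens), read by BRET and beta-arrestin recruitment; on this read-out lower numbers stand for smaller maximal responses and higher numbers for larger maximal responses. Compound 3 `O=C(O)Cc1sc(C(c2ccccc2)c2ccc(Cl)cc2)nc1-c1ccc(Cl)cc1` gives 80%, level with compound 1 at the digits shown and within the scatter, so no order between the two can be read. Compound 2 `Nc1nc(-c2ccc(Cl)cc2)c(CC(=O)O)s1` gives 50%, a number well below compound 1 and beyond the scatter; compound 1 and compound 3 together hold the highest numbers of the three. Compound 4 `O=C(O)Cc1sc(C(c2ccc(F)cc2)c2ccc(F)cc2)nc1-c1cccc(F)c1` is not yet measured in this assay. It differs from compound 1 in one place: 3-fluorophenyl in place of 3-cyano-4-fluorophenyl on an aromatic carbon. Compound 3 carries another aryl group on that aromatic carbon and gives 80%, level with compound 1. The step is therefore expected to stay within the scatter, estimated as a number 2 percentage points lower from compound 1 to compound 4 (within the scatter). For compound 4 the expected value is 78%, ranging from 62% to 92%.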

Compound 4, largest response reached (reported as efficacy), in percent of the reference or control that the assay uses: 80%
Estimate against measurement, compound 4: 2 percentage points below; low and high end bracket the measured number.
By their numbers in this assay, from the lowest: compound 2; then compounds 1, 3 and 4 (each within the scatter of the next).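

In this assay, 3-fluorophenyl in place of 3-cyano-4-fluorophenyl on this aromatic carbon gives no change at the digits printed from compound 1 to compound 4 (within the scatter). Going by these compounds alone, this is the first one-place reading: at this position, the response does not depend on keeping the nitrile or the second fluorine of compound 1. No measurement of any other kind bears on this result. Still open, on these data alone, is how an unsubstituted phenyl, a pyridyl ring or an aminomethyl group on this aromatic carbon would read out. Within the data shown here, the shared core offers no one-place step at any other position.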